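Taking the hydroxy group off compound 1

The compounds below may be only part of what the source reports. "The series", "measured", "known", "first", "only" and "open" are said of these compounds alone.

Among the measured compounds shown here, in a physicochemical assay for lipophilicity (on this read-out higher numbers stand for higher lipophilicity and lower numbers for lower lipophilicity), compound 1 (`Cc1cc(C(=O)N[C@H]2CC[C@@H](NC(=O)c3cc(F)cnc3Oc3cccc(-c4cccc(CN5C[C@@H](C)N[C@@H](C)C5)c4O)c3)CC2)nn1C`) gives 2.8 and holds the highest of the three numbers so far. Compound 3 (`Cc1cc(C(=O)N[C@H]2CC[C@@H](NC(=O)c3cc(F)cnc3Oc3cccc(-c4ccc(CCCN5C[C@@H](C)N[C@@H](C)C5)cc4)c3)CC2)nn1C`) gives 2.6 and stays within the scatter of compound 1, while compound 2 (`Cc1cc(C(=O)N[C@H]2CC[C@@H](NC(=O)c3cc(F)cnc3Oc3cccc(-c4ccc(CN5C[C@@H](C)N[C@@H](C)C5)cc4)c3)CC2)nn1C`) gives 2.4 and lies beyond that scatter. Compound 4 (`Cc1cc(C(=O)N[C@H]2CC[C@@H](NC(=O)c3cc(F)cnc3Oc3cccc(-c4cccc(CN5C[C@@H](C)N[C@@H](C)C5)c4)c3)CC2)nn1C`) differs from compound 1 by a single change (hydrogen in place of hydroxy on an aromatic carbon): hydrogen in place of hydroxy on an aromatic carbon. For the measured compounds named here, no measured step isolates this change. Going by the values given here, the one step between measured compounds that differ in one place (a number 0.20 log units higher from compound 2 to compound 3 (within the scatter)) concerns a chain and not the hydroxy, so it gives no direct guide. Compound 2 also lacks the hydroxy but differs from compound 1 in a second place, so its gap is only a loose hint of a fall. In this assay a small downward step is therefore expected (a number 0.30 log units lower from compound 1 to compound 4 (within the scatter)). Compound 4 is estimated at 2.5 (expected range 2.1 to 2.9).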

Compound 4, distribution coefficient: 2.1
For compound 4 the middle estimate is 0.40 log units above the measured one, and the stated range covers the measured number.
By their numbers in this assay, from the lowest: compounds 4, 2, 3 and 1 (each within the scatter of the next, the first and the last beyond it).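

Among the compounds shown here, replacing hydroxy with hydrogen on this aromatic carbon, ortho to a (3,5-dimethylpiperazin-1-yl)methyl group, gives in this assay a number 0.70 log units lower from compound 1 to compound 4 (beyond the scatter) and so isolates this single change for the first time. Losing one oxygen atom at this place is enough to move the number beyond the scatter, which no earlier pair of compounds could show for this position. Nothing at hand explains why the number falls with this change.

Open, as far as these compounds go, is whether another group on this aromatic carbon, such as methoxy, fluorine or an amine, would keep the number near that of compound 1 or bring it closer to that of compound 4. Also open, from the compounds shown here alone, is whether the same change would give a step of similar size alongside the longer chain of compound 3.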